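The source may hold more compounds than are shown below. What is called first, only, known or untested is meant among the compounds shown, and "the series" means these compounds.

Working notes on the series. Compound 1 `COc1ccc(/C=C2\S/C(=N\c3csc(-c4ccc(Cl)cc4)c3)NC2=O)cc1` gives 1300 nM in a functional assay on HCT-116 cells (Homo sapiens) for cytotoxicity, read by MTT assay, with a stated time of 72 h; a higher number here means a weaker inhibitor, a lower number a stronger inhibitor. Going by the values given here, compound 2 `O=C1N/C(=N/c2csc(-c3ccc(Cl)cc3)c2)S/C1=C\c1ccc2ccccc2c1` gives 3000 nM in this assay, the highest of the two numbers known so far; the only step onto it, a 2.3-fold higher number from compound 1 to compound 2 (0.36 log units; beyond the scatter), is modest but beyond the scatter. Compound 3 `O=C1N/C(=N/c2csc(-c3ccc(Cl)cc3)c2)S/C1=C\c1ccccn1` carries the change (pyridin-2-yl in place of naphthalen-2-yl on a double-bonded chain carbon bound to a double-bonded ring carbon). Among the compounds with values here, the one measured step that bears on it is the swap of the aryl group at the same place, a 2.3-fold higher number from compound 1 to compound 2 (0.36 log units; beyond the scatter), which moved the number only modestly; a change of the same kind at the same place is therefore expected to move this assay by a step of comparable size, with the direction not fixed by the data, since nothing here tells whether the smaller aryl of compound 1 with 1300 nM or the pyridin-2-yl group is the better comparator. For compound 3 the expected step is a 1.7-fold lower number from compound 2 to compound 3 (0.22 log units; within the scatter), giving an estimate of 1800 nM with a range from 700 nM to 4500 nM.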

Compound 3, half-maximal inhibitory concentration: 21600 nM
The estimate for compound 3 lay 12-fold (1.08 log units) below the measured number, and the stated range ends below it.
By their numbers in this assay, from the lowest: compound 1; then compound 2; then compound 3.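

The position on a double-bonded chain carbon bound to a double-bonded ring carbon is more sensitive in this assay than the first pair suggested: pyridin-2-yl in place of naphthalen-2-yl gives a 7.2-fold higher number from compound 2 to compound 3 (0.86 log units; beyond the scatter) and stays a clear loss, while pyridin-2-yl in place of 4-methoxyphenyl gives a 17-fold higher number from compound 1 to compound 3 (1.22 log units; beyond the scatter) and is a large loss. Among these three compounds, the only group with a ring nitrogen gives the highest number, and the two aryl groups of carbon-only rings both give lower numbers. Nothing measured here accounts for this loss. Compound 3 differs from compound 2 both in ring nitrogen and in ring count, so these two changes cannot be separated. A plain phenyl group or pyridin-3-yl at this place would bear on that, and a 4-aminophenyl group would extend the comparison with compound 1.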